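Aryl substituent swap in a phenethyl urea series

The source may report more compounds than this note shows. Statements on the series, on what has been measured and on what is new or still open speak of the compounds shown alone.

Measured compounds:
compound 1 `Cc1ccc(NC(=O)N[C@@H](C)c2ccccc2)cc1`: 100%
compound 2 `CCCc1ccc(NC(=O)N[C@@H](C)c2ccccc2)cc1`: 97%
compound 3 `C[C@H](NC(=O)Nc1ccc(C(F)(F)F)cc1)c1ccccc1`: 94%

In an ADME assay on the whole organism with Oryza sativa as the target, tested at 0.1 uM (on this read-out lower numbers stand for a stronger effect and higher numbers for a weaker effect at the one concentration tested), compound 3 gives 94%, the lowest of the three numbers, yet the steps of a number 6 percentage points lower from compound 1 to compound 3 (within the scatter) and a number 3 percentage points lower from compound 2 to compound 3 (within the scatter) both lie within the scatter, so the three aryl substituents tried so far cannot be told apart on this read-out.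

Compound 4 `CCOC(=O)c1ccc(NC(=O)N[C@@H](C)c2ccccc2)cc1` differs from compound 3 by ethoxycarbonyl in place of trifluoromethyl on an aromatic carbon. Within the data shown here, no measured step exchanges trifluoromethyl for ethoxycarbonyl, so the bearing of earlier steps is indirect: the substituent changes a number 3 percentage points lower from compound 1 to compound 2 (within the scatter) and a number 6 percentage points lower from compound 1 to compound 3 (within the scatter), which also swap one group on this aromatic carbon for another, were small and within the scatter. The ethoxycarbonyl brings two hydrogen-bond acceptors the earlier groups lacked, but nothing measured shows what that does here.

Compound 4 is therefore expected to stay near the three measured numbers, with a number 2 percentage points higher from compound 3 to compound 4 (within the scatter) as the estimated step. Compound 4 is estimated at 96%, within 86% to 100%.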

Compound 4, a percentage reported as activity, at one concentration (the size of the read-out at that concentration, not a potency): 99%
Compound 4: middle estimate off by 3 percentage points, on the low side; low and high end bracket the measured number.
By their numbers in this assay, from the lowest: compounds 3, 2, 4 and 1 (each within the scatter of the next).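

Among these compounds, the ethoxycarbonyl is the only group here with hydrogen-bond acceptors, yet in this assay it gives no step beyond the scatter, with a number 5 percentage points higher from compound 3 to compound 4 (within the scatter) and a number 2 percentage points higher from compound 2 to compound 4 (within the scatter) and a number 1 percentage points lower from compound 1 to compound 4 (within the scatter). Methyl, propyl, trifluoromethyl and ethoxycarbonyl on this aromatic carbon, para to a large group, thus all lie within the scatter of one another, so this change adds no separation to the series on this read-out. No evidence on the cause of this flat result is available.

As far as these compounds go, it remains open whether any group on this aromatic carbon can move the number beyond the scatter, for instance an amine, a carboxylic acid or a longer chain. The compounds shown also leave open whether changes elsewhere on the shared core would do so.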